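The source may hold more compounds than are shown below. What is called first, only, known or untested is meant among the compounds shown, and "the series" means these compounds.

Compound 1 `COc1cc(-c2cc(/C=C/C(=O)c3ccc(Cl)c(Cl)c3)[nH]n2)cc(OC)c1OC` and compound 2 `COc1ccc(-c2cc(/C=C/C(=O)c3ccc(N)cc3)[nH]n2)cc1OC` have both been run in a functional assay on TK-10 cells (Homo sapiens) for inhibition, read by sulforhodamine B assay, with a stated time of 48 h; on this read-out lower numbers stand for stronger inhibition of growth and higher numbers for weaker inhibition of growth. Compound 1 gives 43200 nM, the highest of the two numbers. Its nearest neighbour, compound 2, gives 23000 nM in this assay, a gap that stays within the scatter, so the two are not ordered against each other.

Compound 3 `COc1ccc(C(=O)/C=C/c2cc(-c3cc(OC)c(OC)c(OC)c3)n[nH]2)cc1OC` is not yet measured. It differs from compound 1 as follows: 3,4-dimethoxyphenyl in place of 3,4-dichlorophenyl on a carbonyl carbon. Among the measured compounds shown here, no measured pair shows this change, so no size of step can be taken from the series. The step from compound 1 to compound 3 in this assay is expected to be a 1.2-fold lower number from compound 1 to compound 3 (0.09 log units; within the scatter), nothing beyond the scatter in either direction. Compound 3 is estimated at 35000 nM, in a range from 15000 nM to 85000 nM.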

Compound 3, concentration for total growth inhibition: 2600 nM
Compound 3: middle estimate off by 13-fold (1.13 log units), on the high side; measured number outside the range, below it.
By their numbers in this assay, from the lowest: compound 3; then compounds 2 and 1 (each within the scatter of the next).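

On a carbonyl carbon of the shared core, the aryl group matters in this assay: 3,4-dimethoxyphenyl in place of 3,4-dichlorophenyl gives a 17-fold lower number from compound 1 to compound 3 (1.22 log units; beyond the scatter) on this single pair. Among the compounds shown here, this is the first step that lies beyond the scatter, so this position is not silent. No measurement at hand accounts for the size of this step.

As far as these compounds go, whether both methoxy groups are needed remains open, as a 4-methoxyphenyl would test. Also open, from the compounds shown here alone, is how a 3,4-dihydroxyphenyl at this position would compare with compound 3 .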